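From phenylsulfanyl to 3-methoxyphenoxy on a shared core

The source may hold more compounds than are shown below. What is called first, only, known or untested is meant among the compounds shown, and "the series" means these compounds.

In a functional assay on Raji cells (Homo sapiens) for antiproliferative activity, read by CCK-8 assay, with a stated time of 48 h (a higher number here means a weaker inhibitor, a lower number a stronger inhibitor), compound 1 `C=CC(=O)N1CCC[C@@H](n2nc(C#CCCc3ccccc3)c3c(N)ncnc32)C1` gives 1620 nM, and compound 2 `C=CC(=O)N1CCC[C@@H](n2nc(C#CCSc3ccccc3)c3c(N)ncnc32)C1` gives 2720 nM. Among the measured compounds shown here, the only measured step, a 1.7-fold higher number from compound 1 to compound 2 (0.23 log units; within the scatter), lies within the scatter, so the two cannot be told apart. Compound 3 `C=CC(=O)N1CCC[C@@H](n2nc(C#CCOc3cccc(OC)c3)c3c(N)ncnc32)C1` differs from compound 2 by one change: 3-methoxyphenoxy in place of phenylsulfanyl on a saturated chain carbon bound to a triple-bonded carbon. For the measured compounds named here, no measured step covers this exact exchange. Going by the values given here, the one available step, phenylsulfanyl in place of benzyl at that same place, stayed within the scatter, so no clear shift is expected in this assay. The expected step is a 1.2-fold lower number from compound 2 to compound 3 (0.07 log units; within the scatter), which would not go beyond the scatter. For compound 3 the estimated value is 2300 nM, with an expected range of 900 nM to 5500 nM.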

Compound 3, half-maximal inhibitory concentration: 1690 nM
The estimate for compound 3 lay 1.4-fold (0.13 log units) above the measured number; measured number inside the range.
By their numbers in this assay, from the lowest: compounds 1, 3 and 2 (each within the scatter of the next).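

In this assay both new comparisons, a 1.6-fold lower number from compound 2 to compound 3 (0.21 log units; within the scatter) and a 1.0-fold higher number from compound 1 to compound 3 (0.02 log units; within the scatter), stay within the scatter. On a saturated chain carbon bound to a triple-bonded carbon, benzyl, phenylsulfanyl and 3-methoxyphenoxy therefore cannot be told apart, even with sulfur leaving and oxygen entering in the last exchange. No measurement at hand accounts for this result. Going by these compounds, whether an amine or a carboxylic acid at this place would move the number beyond the scatter remains open. So does the separate contribution of the methoxy group, which enters here together with the phenoxy oxygen.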